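A few compounds are considered here, and "the series" means these few. Any claim that something is new, unique, unknown or untested is made for them only; others in the source may bear on it.

In a functional assay on CNE-2 cells (Homo sapiens) for cytotoxicity, read by sulforhodamine B assay, with a stated time of 48 h (a higher number here means a weaker inhibitor, a lower number a stronger inhibitor), compound 1 `COc1ccc(/C=C/C(=O)c2cccc(-c3ccc(F)cc3)c2)cc1` gives 5550 nM and compound 3 `COc1ccccc1/C=C/C(=O)c1cccc(-c2cccc(F)c2)c1` gives 10400 nM and these two numbers lie within the scatter of each other. For compound 2 `COc1ccc(/C=C/C(=O)c2cccc(-c3cccc(F)c3)c2)cc1O` the entry is "not determined" (no result reported) and so it offers no comparison. Compound 4 `COc1ccc(/C=C/C(=O)c2cccc(-c3cccc(F)c3)c2)cc1` has the same atoms as compound 3 joined differently, with 4-methoxyphenyl in place of 2-methoxyphenyl on a double-bonded chain carbon bound to a double-bonded chain carbon as the change. Going by the values given here, no measured pair isolates this change. Compound 1 carries the same 4-methoxyphenyl and gives 5550 nM in this assay so a small shift to a lower number is expected, with nothing beyond the scatter. The expected change is a 1.6-fold lower number from compound 3 to compound 4 (0.20 log units; within the scatter) and it is estimated to stay small. For compound 4 the estimated value is 6500 nM with an expected range from 2500 nM to 16000 nM in this measurement.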

Compound 4, half-maximal inhibitory concentration: 740 nM
Compound 4: middle estimate off by 8.8-fold (0.94 log units), on the high side; the whole stated range lies above it.
By their numbers in this assay, from the lowest: compound 4; then compounds 1 and 3 (each within the scatter of the next).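

In this assay the change to 4-methoxyphenyl in place of 2-methoxyphenyl on a double-bonded chain carbon bound to a double-bonded chain carbon gives a 14-fold lower number from compound 3 to compound 4 (1.15 log units; beyond the scatter) and shows that this position responds strongly to where the methoxy group stands. The fluorine's place also counts: 3-fluorophenyl in place of 4-fluorophenyl on an aromatic carbon gives a 7.5-fold lower number from compound 1 to compound 4 (0.88 log units; beyond the scatter) and neither change could be read alone before. Nothing measured here explains either step. Going by these compounds, whether an amine or a carboxylic acid in place of the methoxy group would keep this level remains open.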